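This account rests on a few compounds, and the source may have more. Where it says the series, first, only, none or still open, it means among the compounds named here.

Measured so far in an assay on HEK293 cells for displacement of a labelled ligand from 5-hydroxytryptamine receptor 7 (Rattus norvegicus); a lower number here means a stronger inhibitor, a higher number a weaker inhibitor:
- compound 1, `CC(C)(C)c1ccccc1N1CCN(CCCCCC(=O)NC2CCCc3ccccc32)CC1`: 538 nM
- compound 2, `O=C(CCCCCN1CCN(c2ccccc2-c2ccccc2)CC1)NC1CCCc2ccccc21`: 0.13 nM
- compound 3, `CS(=O)(=O)Nc1ccccc1N1CCN(CCCCCC(=O)NC2CCCc3ccccc32)CC1`: 4250 nM

Compound 3 gives the highest number of the three in this assay. Its nearest neighbour is compound 1, and the step of a 7.9-fold higher number from compound 1 to compound 3 (0.90 log units; beyond the scatter) separates them; compound 2 lies furthest away, with the step of a 33000-fold higher number from compound 2 to compound 3 (4.51 log units; beyond the scatter) between them. Both measured steps that end at compound 3 therefore show that the methanesulfonamido group on the aromatic carbon goes together with a weaker result than either tert-butyl or phenyl in that position.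

Compound 4, `O=C(CCCCCN1CCN(c2ccccn2)CC1)NC1CCCc2ccccc21`, has not yet been measured. It differs from compound 3 in one place: pyridin-2-yl in place of 2-(methanesulfonamido)phenyl on an amine nitrogen in a ring. Among the compounds with values here, no measured step shows this exact change; the steps that bear on it are those in which the methanesulfonamido group is exchanged, namely a 7.9-fold higher number from compound 1 to compound 3 (0.90 log units; beyond the scatter) and a 33000-fold higher number from compound 2 to compound 3 (4.51 log units; beyond the scatter), one modest and one large, both in the direction of higher numbers when that group is present. Removing it is therefore expected to bring the number down again, though the pyridin-2-yl ring carries no substituent at all, so the size is uncertain. For compound 4 in this assay an estimated step of a 14-fold lower number from compound 3 to compound 4 (1.15 log units; beyond the scatter) is expected, giving an expected value of about 300 nM, within a range from 30 nM to 3000 nM.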

Compound 4, inhibition constant: 278 nM
The estimate for compound 4 lay 1.1-fold (0.03 log units) above the measured number; measured number inside the range.
By their numbers in this assay, from the lowest: compound 2; then compounds 4 and 1 (each within the scatter of the next); then compound 3.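

In this assay the step of a 15-fold lower number from compound 3 to compound 4 (1.18 log units; beyond the scatter) shows that the shared core does not by itself carry the high number of compound 3: with pyridin-2-yl on the ring amine nitrogen, the number comes down substantially. The step of a 1.9-fold lower number from compound 1 to compound 4 (0.29 log units; within the scatter) lies within the scatter, so this ring without a substituent cannot be told apart from 2-(tert-butyl)phenyl at this position. The step of a 2100-fold higher number from compound 2 to compound 4 (3.33 log units; beyond the scatter) then sets 2-phenylphenyl apart from pyridin-2-yl, just as it stands apart from the other two groups.

Going by these compounds, it remains open whether the pyridin-2-yl ring nitrogen or the absence of a substituent matters more, and a plain phenyl ring or a 2-methoxyphenyl group would bear on that. Nothing available gives a reason for any of these steps.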